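This account rests on a few compounds, and the source may have more. Where it says the series, first, only, none or still open, it means among the compounds named here.

Compound 3 `CC(=O)Oc1ccccc1C(=O)Nc1c(C#N)[n+]([O-])c2ccccc2[n+]1[O-]` was carried into an ADME assay on cells (Peritoneal macrophage cell, Mus musculus) for cytotoxicity, read by trypan blue exclusion, with a stated time of 48 h (a higher number here means that more compound is tolerated, a lower number that less compound is tolerated), and for compound 3 the entry there reads "not determined" (no result reported): compound 3 stands with no number in this assay. Two related compounds of the same study did give values there. In this assay compound 1 `N#Cc1c(NS(=O)(=O)c2ccc3ccccc3c2)[n+]([O-])c2ccc(Cl)cc2[n+]1[O-]` gives 88600 nM. In this assay compound 2 `N#Cc1c(NS(=O)(=O)c2ccccc2[N+](=O)[O-])[n+]([O-])c2ccc(Cl)cc2[n+]1[O-]` gives 6800 nM. Those two values lie far apart, and neither compound shares the amide of compound 3, so they set only a broad frame. Compound 4 `CC(=O)Oc1ccccc1C(=O)Nc1c(C#N)[n+]([O-])c2cc(F)ccc2[n+]1[O-]` differs from compound 3 by fluoro in place of hydrogen on an aromatic carbon, a fluoro in place of hydrogen on an aromatic carbon. Going by the values given here, with no step of this kind recorded among the measured compounds, the size of the step in this assay is expected to be small, in no settled direction, and likely within the scatter. Compound 4 is therefore expected to give about 20000 nM in this assay, estimated to fall between 4000 nM and 100000 nM.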

Compound 4, half-maximal cytotoxic concentration: 13600 nM
Estimate against measurement, compound 4: 1.5-fold (0.17 log units) above, and the stated range covers the measured number.
By their numbers in this assay, from the lowest: compounds 2 and 4 (each within the scatter of the next); then compound 1.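

No new step can be read: compound 3 has no number in this assay, so compound 4 at 13600 nM has no partner for comparison. The compounds shown leave open what fluoro in place of hydrogen does there, and no evidence bears on this result.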